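The compounds below may be only part of what the source reports. "The series", "measured", "known", "first", "only" and "open" are said of these compounds alone.

Compound 2, `O=S(=O)(NCCCNCc1ccc(C(F)(F)F)cc1)c1cc(C(F)(F)F)cc(C(F)(F)F)c1`, in a functional assay on HPAC cells (Homo sapiens) for inhibition, read by MTT assay, with a stated time of 72 h; a lower number here means a stronger inhibitor of growth, a higher number a weaker inhibitor of growth: 2700 nM
Compound 3, `O=S(=O)(NCCCNCc1ccc(-c2ccccc2)cc1)c1cc(C(F)(F)F)cc(C(F)(F)F)c1`: 2700 nM
Compound 1, `O=S(=O)(NCCNCc1cccc2ccccc12)c1cc(C(F)(F)F)cc(C(F)(F)F)c1`: 18000 nM

Compound 2 stands level with compound 3 within the scatter, the two together giving the lowest numbers of the three, while compound 1 gives a higher number, beyond the scatter. Compound 4, `COc1cccc(CNCCCNS(=O)(=O)c2cc(C(F)(F)F)cc(C(F)(F)F)c2)c1`, differs from compound 2 in one place: 3-methoxyphenyl in place of 4-(trifluoromethyl)phenyl on a saturated chain carbon bound to an amine nitrogen. For the measured compounds named here, the only measured step that bears on this also changes a substituent on the same aromatic ring: no change at the digits printed from compound 2 to compound 3 (within the scatter). That step moved nothing beyond the scatter, so the expectation for compound 4 is a step of about a 1.1-fold higher number from compound 2 to compound 4 (0.05 log units; within the scatter) in this assay, neither clearly up nor down. Compound 4 is therefore estimated at 3000 nM, with a range from 1200 nM to 8000 nM.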

Compound 4, concentration for 50% growth inhibition: 2400 nM
Compound 4: the middle estimate sits 1.3-fold (0.10 log units) above what was measured; low and high end bracket the measured number.
By their numbers in this assay, from the lowest: compounds 4, 2 and 3 (each within the scatter of the next); then compound 1.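

Swapping 4-(trifluoromethyl)phenyl for 3-methoxyphenyl gives a 1.1-fold lower number from compound 2 to compound 4 (0.05 log units; within the scatter) in this assay. Unlike the step to compound 3, this change removes all the fluorine from the group and brings in a hydrogen-bond acceptor, so this position has now kept its level across three different ring substituents, although compound 1 is not part of that comparison. On these data alone, what an amine or a carboxylic acid on this ring would do remains open. The data shown offer no measurement that explains why the number holds here.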